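A few compounds are considered here, and "the series" means these few. Any claim that something is new, unique, unknown or untested is made for them only; others in the source may bear on it.

Measured so far in a functional assay on L1210 cells (Mus musculus) for antiproliferative activity, read by MTT assay, with a stated time of 72 h; a higher number here means a weaker inhibitor, a lower number a stronger inhibitor:
- compound 1 `COc1ccc(C2OC(c3cc(OC)c(OC)c(OC)c3)=NN2C(C)=O)cc1OC(C)=O`: 3900 nM
- compound 2 `COc1ccc(C2=NN(C(C)=O)C(c3ccc([N+](=O)[O-])cc3)O2)cc1`: 68000 nM

Of these two numbers, compound 2 stands highest at 68000 nM, and so is the weaker inhibitor. Compound 1 gives 3900 nM. The gap between these two numbers lies well beyond the scatter. Compound 3 `COc1ccc(C2=NN(C(C)=O)C(c3ccccc3)O2)cc1` has not yet been measured in this assay. It puts hydrogen in place of nitro on an aromatic carbon of compound 2 (hydrogen in place of nitro on an aromatic carbon). Among the measured compounds shown here, no measured pair in this set differs in only one place, so the data offer no direct guide to the size of this change. A step no larger than the scatter is therefore expected, leaning slightly towards a lower number, with the estimate being a 1.7-fold lower number from compound 2 to compound 3 (0.23 log units; within the scatter). For compound 3 the expected value is 40000 nM, with an estimated range of 11000 nM to 140000 nM.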

Compound 3, half-maximal inhibitory concentration: > 100000 nM
Compound 3: only a limit was reported; the forecaster's own chance of this, stated with the estimate: 20%; at least 2.5-fold (0.39 log units) between middle value and limit.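

In this assay, compound 3 gives > 100000 nM, which is a limit of the assay and not a number. Hydrogen in place of nitro on an aromatic carbon, para to a large group, gives an at least 1.4-fold higher number from compound 2 to compound 3 (0.16 log units; that floor lies within the scatter), the first single-place step in this set, so the nitro group cannot be dropped here with any sign of a lower number, although the floor of the step alone does not clear the scatter. The true size of the step stays unfixed because the reading stops at the limit: the limit of > 100000 nM in this assay, at which 1 of the 3 values shown sits.

The compounds shown leave open how an amine, a nitrile or a carboxylic acid at this place would read in this assay. They also leave open whether the same exchange of nitro for hydrogen would give a similar step on the core of compound 1.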